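This account rests on a few compounds, and the source may have more. Where it says the series, first, only, none or still open, it means among the compounds named here.

Compound 2 `Cc1coc2c3c(ccc2c1=O)OC[C@H]1[C@@H]3Nc2cc3ccccc3cc2C1(C)C` gives 9000 nM in a functional assay on MCF7 cells (Homo sapiens) for antiproliferative activity, read by MTT assay; a lower number here means a stronger inhibitor, a higher number a weaker inhibitor. Compound 1 `Cc1oc2c3c(ccc2c(=O)c1C)OC[C@H]1[C@@H]3Nc2cc3ccccc3cc2C1(C)C` differs from it by a single change (methyl in place of hydrogen on an aromatic carbon). In this assay compound 1 gives only a limit, > 100000 nM. The step of an at least 11-fold higher number from compound 2 to compound 1 (1.04 log units; beyond the scatter) therefore runs against the added methyl, though the limit of > 100000 nM in this assay, at which 2 of the 3 values shown sit, leaves its full size open. Compound 3 `Cc1oc2c3c(ccc2c(=O)c1-c1ccccc1)OC[C@H]1[C@@H]3Nc2ccccc2C1(C)C` rests on another core; the difference between the two cores is not broken down here. In this assay compound 3 likewise gives only a limit, > 100000 nM. Compound 4 `Cc1ccc2c(c1)C(C)(C)[C@H]1COc3ccc4c(=O)c(-c5ccccc5)c(C)oc4c3[C@H]1N2` is made from compound 3 by the same kind of change (methyl in place of hydrogen on an aromatic carbon), here on a six-membered aromatic ring of carbon only, meta to a fused ring and para to a fused ring, rather than next to the ring oxygen and ortho to a methyl group. Because the limit of > 100000 nM in this assay, at which 2 of the 3 values shown sit, already holds compound 3, compound 4 is expected to stay near that limit, with an estimated step of a number no higher from compound 3 to compound 4 (the limit leaves the size open). Compound 4 is estimated at 100000 nM, between 20000 nM and 500000 nM.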

Compound 4, half-maximal inhibitory concentration: 10000 nM
Beside the measured number, compound 4's estimate is 10-fold (1.00 log units) above it; measured number below the stated range.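

In this assay, methyl in place of hydrogen on an aromatic carbon gives an at least 10-fold lower number from compound 3 to compound 4 (1.00 log units; beyond the scatter), so the change does not carry over between these two cores, even in direction: the same change on two cores in this assay, an at least 11-fold higher number (1.04 log units; beyond the scatter) from compound 2 to compound 1 and an at least 10-fold lower number (1.00 log units; beyond the scatter) from compound 3 to compound 4, at least 110-fold (2.04 log units) apart, beyond the scatter of two such steps. Compound 1 and compound 3 each stand at a limit of the assay, which leaves the full size of both steps open: the limit of > 100000 nM in this assay, at which 2 of the 4 values shown sit. The two methyl groups also sit at different places, so this pair of steps does not show whether the core or the position accounts for the gap, nor why the steps differ.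

The compounds shown leave open how methyl at one place would behave on both cores. They also leave open whether an ethyl group or a chlorine there would follow the methyl.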